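A few compounds are considered here, and "the series" means these few. Any claim that something is new, unique, unknown or untested is made for them only; others in the source may bear on it.

In a functional assay on PC-3 cells (Homo sapiens) for antiproliferative activity, read by MTT assay, with a stated time of 72 h (on this read-out lower numbers stand for stronger inhibition and higher numbers for weaker inhibition), compound 2 `CCCCCCCCCNC[C@@H]1OC[C@H](N)[C@H]1O` gives 7650 nM. That number lies within the usual scatter of compound 1 `CCCCCCCCCCNC[C@@H]1OC[C@H](N)[C@@H]1O` at 11900 nM, and well above compound 3 `CCCCCCCCCCCCNC[C@@H]1OC[C@H](N)[C@@H]1O` at 850 nM. Compound 4 `CCCCCCCCNC[C@@H]1OC[C@H](N)[C@H]1O` has not yet been measured. The change from compound 2 is hydrogen in place of methyl on a saturated chain carbon, eight bonds along the chain from an amine nitrogen. This trims the end of the chain.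

Going by the values given here, one measured step bears on this change: a 14-fold lower number from compound 1 to compound 3 (1.15 log units; beyond the scatter), a large step in which ethyl replaces hydrogen on a saturated chain carbon. There, a longer chain came with a lower number. Compound 4 moves the opposite way and by a smaller piece, so a smaller step towards a higher number is expected, although this rests on a single pair. In this assay, the expected step is a 2.9-fold higher number from compound 2 to compound 4 (0.46 log units; beyond the scatter). Compound 4 is estimated at 22000 nM, with an expected range from 11000 nM to 45000 nM.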

Compound 4, half-maximal inhibitory concentration: 13000 nM
For compound 4 the middle estimate is 1.7-fold (0.23 log units) above the measured one; the range from low to high includes it.
By their numbers in this assay, from the lowest: compound 3; then compounds 2, 1 and 4 (each within the scatter of the next).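

In this assay, hydrogen in place of methyl on a saturated chain carbon, eight bonds along the chain from an amine nitrogen, gives a 1.7-fold higher number from compound 2 to compound 4 (0.23 log units; within the scatter), so this small trim cannot be told apart from no change. The earlier chain step, a 14-fold lower number from compound 1 to compound 3 (1.15 log units; beyond the scatter), was large, but it involved ethyl rather than methyl, a different chain length and a core whose spatial arrangement differs from that of compound 2, so the two steps do not make one trend. Nothing available explains why the trim matters so little here.

Still open, going by these compounds, is whether a longer chain on the core of compound 2 would reach numbers like that of compound 3 at 850 nM. Also open, on these data alone, is how a phenyl group at the chain end would compare with plain chain carbons.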